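The compounds below may be only part of what the source reports. "The series", "measured", "known", "first", "only" and "open" are said of these compounds alone.

Compound 1 `CC(C)=CCC[C@H](C)c1ccc(C)c(CNCCO)c1O`: > 20000 nM, a limit
Compound 2 `CC(C)=CCC[C@H](C)c1ccc(C)c(CNCCCCCO)c1O`: 7600 nM

Going by the values given here, in a functional assay on MCF7 cells (Homo sapiens) for inhibition, read by MTT assay, with a stated time of 72 h (a lower number here means a stronger inhibitor, a higher number a weaker inhibitor), compound 2 gives 7600 nM, the only actual number so far. The other value, for compound 1, is a limit.

Compound 3 `CCOC(CCNCc1c(C)ccc([C@@H](C)CCC=C(C)C)c1O)OCC` carries diethoxymethyl in place of 3-hydroxypropyl on a saturated chain carbon, two bonds along the chain from an amine nitrogen; the same change reads as 5-hydroxypentyl to 3,3-diethoxypropyl: diethoxymethyl in place of 3-hydroxypropyl on a saturated chain carbon, two bonds along the chain from an amine nitrogen.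

Among the compounds with values here, one measured step bears on this place: an at least 2.6-fold lower number from compound 1 to compound 2 (0.42 log units; beyond the scatter). It lies beyond the scatter and shows that this assay responds to a change at this place, but it gives no direction for the new group. The expected 1.3-fold lower number from compound 2 to compound 3 (0.10 log units; within the scatter) is therefore no step beyond the scatter. For compound 3 the estimated value is 6000 nM, with an expected range from 2500 nM to 16000 nM.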

Compound 3, half-maximal inhibitory concentration: 10300 nM
Estimate against measurement, compound 3: 1.7-fold (0.23 log units) below, and the stated range covers the measured number.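

In this assay, 5-hydroxypentyl to 3,3-diethoxypropyl gives a 1.4-fold higher number from compound 2 to compound 3 (0.13 log units; within the scatter), so the two compounds are not separated, although the entering group has 0 hydrogen-bond donors and 7 heavy atoms against 1 donor and 4 heavy atoms in the group it replaces; in this pair, the free hydroxy is not required to hold the number of compound 2. Against the short hydroxy chain, the reading is an at least 1.9-fold lower number from compound 1 to compound 3 (0.28 log units; that floor lies within the scatter), so this floor alone does not separate compound 3 from compound 1. Compound 1 carries a limit, not a number: the limit of > 20000 nM in this assay, at which 1 of the 3 values shown sits.

On these data alone, whether a carboxylic acid or a primary amine at the end of this chain would move the number beyond the scatter remains open. So does whether a longer chain than 5-hydroxypentyl would lower it further.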